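The compounds below may be only part of what the source reports. "The series", "measured", "known", "first", "only" and "open" are said of these compounds alone.

Of the compounds shown here, three sharing one core have been measured in an assay on cells for binding affinity to Neuropeptide Y receptor type 1 (Homo sapiens); a higher number here means a weaker inhibitor, a lower number a stronger inhibitor. Compound 1 `CCCCOc1cc(CCc2nc(C)c(CC)s2)nc(NCc2cc(Cl)cc(NC(=O)OC(C)C)c2)c1` gives 16 nM. Compound 2 `CCCCCOc1cc(CCc2nc(C)c(CC)s2)nc(NCc2cc(Cl)cc(NC(=O)OC(C)C)c2)c1`, which carries a longer chain on the ring oxygen, gives 35 nM, a step of a 2.2-fold higher number from compound 1 to compound 2 (0.34 log units; beyond the scatter). Compound 3 `CC/C=C\CCOc1cc(CCc2nc(C)c(CC)s2)nc(NCc2cc(Cl)cc(NC(=O)OC(C)C)c2)c1`, whose chain holds a double bond, gives 4.7 nM; the steps of a 3.4-fold lower number from compound 1 to compound 3 (0.53 log units; beyond the scatter) and a 7.4-fold lower number from compound 2 to compound 3 (0.87 log units; beyond the scatter) both lie beyond the scatter, so compound 3 is the strongest binder of the three.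

Compound 4 `CCc1sc(CCc2cc(OC(CC)CC)cc(NCc3cc(Cl)cc(NC(=O)OC(C)C)c3)n2)nc1C` changes the chain once more: pentan-3-yl in place of hex-3-en-1-yl on an oxygen on an aromatic ring. Going by the values given here, the new chain has no double bond and is branched, a shape no measured compound shows. The most relevant step is a 3.4-fold lower number from compound 1 to compound 3 (0.53 log units; beyond the scatter), which suggests that removing the double bond costs affinity; the step of a 2.2-fold higher number from compound 1 to compound 2 (0.34 log units; beyond the scatter) shows that a longer saturated chain also weakened binding. A step back toward the range of compound 1, a 4.3-fold higher number from compound 3 to compound 4 (0.63 log units; beyond the scatter), is therefore expected. Compound 4 is estimated at 20 nM, with a likely range from 7 nM to 60 nM.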

Compound 4, half-maximal inhibitory concentration: 5.5 nM
Estimate against measurement, compound 4: 3.6-fold (0.56 log units) above, and the stated range ends above it.
By their numbers in this assay, from the lowest: compounds 3 and 4 (each within the scatter of the next); then compound 1; then compound 2.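

In this assay, a double bond in the chain is not needed for a low number at this oxygen on an aromatic ring: replacing hex-3-en-1-yl with saturated pentan-3-yl gives a 1.2-fold higher number from compound 3 to compound 4 (0.07 log units; within the scatter). Straight saturated chains do not predict this result, as branched pentan-3-yl gives both a 6.4-fold lower number from compound 2 to compound 4 (0.80 log units; beyond the scatter) and a 2.9-fold lower number from compound 1 to compound 4 (0.46 log units; beyond the scatter), so the arrangement of a saturated chain at this position can change the number beyond the scatter. No supporting data are available to explain these differences.

The compounds shown leave open how a straight hexyl chain would compare with hex-3-en-1-yl, and therefore what the double bond itself contributes. They also leave open whether another branched group, such as propan-2-yl, or a ring, such as cyclopentyl, would give a similar number.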